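The compounds below may be only part of what the source reports. "The series", "measured", "known", "first", "only" and "open" are said of these compounds alone.

Measured so far in a physicochemical assay for lipophilicity; a higher number here means a more lipophilic compound, a lower number a more polar compound
- compound 1 `COc1c(OC)c(OC(C)=O)c2c(OC)cccc2c1OC(C)=O` gives 2.43
- compound 2 `COc1c(OC)c(OC(=O)C(C)(C)C)c2cc(C)c(C)cc2c1OC(=O)C(C)(C)C` gives 6.5

Compound 1 stands lowest of the two measured compounds, and compound 2 lies above it by more than the scatter. Compound 3 `COc1c(OC)c(OC(C)=O)c2c(Sc3ccccc3)cccc2c1OC(C)=O` has not yet been measured. It keeps the core of compound 1 but carries phenylsulfanyl in place of methoxy on an aromatic carbon. Among the measured compounds shown here, no two measured compounds differ in just one place, so the data offer no direct guide to the size of this step. Set against compound 1 in more than one place, compound 2 serves only as a loose upper reference (6.5). In this assay a rise well beyond the scatter is expected (a number 2.27 log units higher from compound 1 to compound 3 (beyond the scatter)). The estimated value for compound 3 is 4.7 (expected range 3.9 to 5.5).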

Compound 3, partition coefficient: 4.2
Estimate against measurement, compound 3: 0.50 log units above; low and high end bracket the measured number.
By their numbers in this assay, from the lowest: compound 1; then compound 3; then compound 2.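

In this assay, among the compounds shown here, phenylsulfanyl in place of methoxy gives the only comparison so far that differs in one place, a number 1.77 log units higher from compound 1 to compound 3 (beyond the scatter), and this step is large. It shows that the number responds strongly to a change at this aromatic carbon, ortho to a fused ring and meta to a fused ring, while the rest of the core of compound 1 stays the same. Nothing shown here accounts for the size of the step.

Going by these compounds, whether the step follows the sulfur or the added six-membered aromatic ring remains open, and a methylsulfanyl or phenoxy group at this carbon would separate the two. On these data alone, how an amine at the same carbon would read also remains open, as does the effect of any other place on the core.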